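The compounds below may be only part of what the source reports. "The series", "measured", "known", "first", "only" and "open" are said of these compounds alone.

Measured in a functional assay on HeLa cells (Homo sapiens) for inhibition, read by MTT assay, with a stated time of 48 h; on this read-out lower numbers stand for stronger inhibition and higher numbers for weaker inhibition:
- compound 1 `COc1ccc2c(=O)c(/C=C/C(=O)Nc3cccc(C)c3)coc2c1`: > 100000 nM, a limit and not a number
- compound 2 `COc1ccc2c(=O)c(/C=C/C(=O)Nc3cccc(Cl)c3)coc2c1`: 11900 nM
- compound 3 `COc1ccc2c(=O)c(/C=C/C(=O)Nc3ccccc3)coc2c1`: > 100000 nM, a limit and not a number

Compound 2 is the only one of the three that gives a number. Compound 1 and compound 3 stand at the limit of > 100000 nM in this assay, at which 2 of the 3 values shown sit.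

Compound 4 `COc1ccc2c(=O)c(/C=C/C(=O)NCc3ccc(F)cc3)coc2c1` has not yet been measured. Compared with compound 2, it carries 4-fluorobenzyl in place of 3-chlorophenyl on an amide-type nitrogen. Among the compounds with values here, no measured step makes this exact exchange, so the evidence is indirect. The nearest guides are two steps on the same aromatic ring. Putting chloro in place of methyl gives an at least 8.4-fold lower number from compound 1 to compound 2 (0.92 log units; beyond the scatter), and putting hydrogen in place of chloro gives an at least 8.4-fold higher number from compound 2 to compound 3 (0.92 log units; beyond the scatter). Among these three compounds, only compound 2 carries chloro and only compound 2 gives a number. Compound 4 has no chloro either, so a higher number than in compound 2 is expected, although the size is uncertain and a limit is possible. The expected step is a 2.9-fold higher number from compound 2 to compound 4 (0.47 log units; beyond the scatter). For compound 4 the estimated value is 35000 nM, with an expected range from 9000 nM to 100000 nM.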

Compound 4, half-maximal inhibitory concentration: > 100000 nM
Compound 4: no number, only a limit; the forecaster's own chance of this, stated with the estimate: 40%; middle value at least 2.8-fold (0.45 log units) from the limit.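

In this assay, within the data shown here, the earlier compounds changed only a small group on the aromatic ring, whereas here the whole group on the amide-type nitrogen is exchanged, and putting 4-fluorobenzyl in place of 3-chlorophenyl gives an at least 8.4-fold higher number from compound 2 to compound 4 (0.92 log units; beyond the scatter). So a halogen on the ring is not enough on its own to give a measurable number: compound 4 carries fluorine, yet its result is a limit and not a number, which puts it with compound 1 and compound 3: the limit of > 100000 nM in this assay, at which 3 of the 4 values shown sit. Among the four compounds, 3-chlorophenyl is still the only group on this nitrogen that gives a number, while the steps from compound 1 and from compound 3 to compound 4 cannot be read, as both ends of each step are limits.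

Compound 4 differs from compound 2 in the kind of halogen, its place on the ring and the benzyl form of the group, and the compounds shown do not separate these three changes. A benzyl group carrying chloro, or a phenyl group carrying fluoro, would pull them apart, and a phenyl group carrying bromo or a nitrile would test whether chloro itself is needed.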